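The compounds below may be only part of what the source reports. "The series", "measured", "known", "first", "only" and "open" are said of these compounds alone.

Within the data shown here, compound 2 `CCCNc1nc(Nc2ccc(OC)cc2)nc2ccccc12` gives the lowest of the two numbers so far in a functional assay on MV4-11 cells (Homo sapiens) for antiproliferative activity, read by MTT assay (a higher number here means a weaker inhibitor of growth, a lower number a stronger inhibitor of growth), at 5880 nM; the nearest is compound 1 `COc1ccc(Nc2nc(NCCCO)c3ccccc3n2)cc1`, which in this assay gives 8750 nM. Among the measured compounds shown here, the one step between them, a 1.5-fold lower number from compound 1 to compound 2 (0.17 log units; within the scatter), lies within the scatter. Compound 3 `COc1ccc(Nc2nc(NC3CC3)c3ccccc3n2)cc1` has not yet been measured in this assay. It differs from compound 2 in one place: cyclopropyl in place of propyl on a nitrogen on an aromatic ring. For the measured compounds named here, no measured step in this set concerns an exchange of the kind seen from compound 2 to compound 3; the only step in the set concerns a hydroxy group on the chain and is small. Nothing in the data therefore points to a change beyond the scatter, and the step from compound 2 to compound 3 is expected to be about a 1.1-fold lower number from compound 2 to compound 3 (0.03 log units; within the scatter). Compound 3 is accordingly estimated to give 5500 nM in this assay, within a range from 2000 nM to 15000 nM.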

Compound 3, concentration for 50% growth inhibition: < 13400 nM
Compound 3 was reported as a limit; the forecaster's own chance of this, stated with the estimate: 5%; the middle value does not contradict the limit.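

Compound 3 is reported only as a limit in this assay, < 13400 nM, so its steps from compound 2 and from compound 1 cannot be read: the limit of < 13400 nM in this assay, at which 1 of the 3 values shown sits.

The compounds shown leave open whether cyclopropyl in place of propyl on a nitrogen on an aromatic ring changes growth inhibition in this assay, and in which direction.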